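This account rests on a few compounds, and the source may have more. Where it says the series, first, only, none or still open, it means among the compounds named here.

Three compounds sharing one core have numbers in a functional assay (Homo sapiens) for inhibition; on this read-out lower numbers stand for stronger inhibition and higher numbers for weaker inhibition. Compound 1 (`COc1cc(/C=C/C(=O)c2ccccc2N(C)C)cc(OC)c1`), which carries dimethylamino, gives 5700 nM. Compound 2 (`COc1cc(/C=C/C(=O)c2ccccc2[N+](=O)[O-])cc(OC)c1`), which carries nitro on the same carbon, gives 3700 nM. Compound 3 (`COc1cc(/C=C/C(=O)c2ccccc2F)cc(OC)c1`), which carries fluoro there, gives 6000 nM, and so stands level with both others within the scatter.

The next step leads from compound 3 to compound 4 (`COc1cc(/C=C/C(=O)c2ccccc2O)cc(OC)c1`), with hydroxy in place of fluoro on an aromatic carbon, ortho to a large group: hydroxy in place of fluoro on an aromatic carbon.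

The measured steps that bear on this are the exchanges at that same carbon: a 1.1-fold higher number from compound 1 to compound 3 (0.02 log units; within the scatter), a 1.6-fold higher number from compound 2 to compound 3 (0.21 log units; within the scatter) and a 1.5-fold lower number from compound 1 to compound 2 (0.19 log units; within the scatter). All three are small, so the three groups measured so far do not separate in this assay. Among the measured compounds shown here, no measured compound carries hydroxy on that carbon, which leaves this exchange without a direct precedent and calls for a wide range. On these steps, no change beyond the scatter is expected, and no firm direction can be given.

The expected step is a 1.3-fold lower number from compound 3 to compound 4 (0.12 log units; within the scatter).

For compound 4 the estimated value is 4500 nM, with an expected range from 1800 nM to 11000 nM.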

Compound 4, half-maximal inhibitory concentration: 8100 nM
Estimate against measurement, compound 4: 1.8-fold (0.26 log units) below; low and high end bracket the measured number.
By their numbers in this assay, from the lowest: compounds 2, 1, 3 and 4 (each within the scatter of the next, the first and the last beyond it).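

In this assay, hydroxy on this aromatic carbon, ortho to a large group, gives the only exchange among these compounds whose size passes the scatter, a modest step (a 2.2-fold higher number from compound 2 to compound 4 (0.34 log units; beyond the scatter)). Against the other two groups hydroxy stays level (a 1.4-fold higher number from compound 3 to compound 4 (0.13 log units; within the scatter); a 1.4-fold higher number from compound 1 to compound 4 (0.15 log units; within the scatter)), so it separates from nitro alone and not from fluoro or dimethylamino. The four groups thus span a narrow band at this position, with only nitro and hydroxy, at its two ends, told apart. Nothing in the data accounts for the gap between these two groups.

On these data alone, whether a primary amine, a methoxy group or a carboxylic acid on this carbon would stay within the same narrow band remains open. Also open, as far as these compounds go, is whether the gap between nitro and hydroxy would persist with other groups on the dimethoxy-bearing part of the shared core, which stays unchanged in all four compounds.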